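Swapping the Halogen on the Aryl Ring: Fluoro to Bromo

A few compounds are considered here, and "the series" means these few. Any claim that something is new, unique, unknown or untested is made for them only; others in the source may bear on it.

Compound 2 `O=C(/N=C/c1ccc(F)cc1)Nc1ccc2c(c1)C(=O)C(=O)N2CN1CCCCC1` is tested in a functional assay on the whole organism (strain Swiss albino) with Mus musculus as the target, with a stated time of 0.5 h (on this read-out lower numbers stand for an effect already at smaller amounts and higher numbers for an effect only at larger amounts of compound), where compound 2 gives 100 mg/kg. Its closest relative, compound 1 `O=C(/N=C/c1ccc(Cl)cc1)Nc1ccc2c(c1)C(=O)C(=O)N2CN1CCCCC1`, gives 100 mg/kg in this assay, so the two stand level. Among the measured compounds shown here, the only measured step, no change at the digits printed from compound 1 to compound 2 (within the scatter), shows that exchanging one halogen for another on an aromatic carbon left the read-out unchanged. Compound 3 `O=C(/N=C/c1ccc(Br)cc1)Nc1ccc2c(c1)C(=O)C(=O)N2CN1CCCCC1` continues this series: bromo in place of fluoro on an aromatic carbon. Because no change at the digits printed from compound 1 to compound 2 (within the scatter) stayed within the scatter, a similar absence of movement is expected here, no change at the digits printed from compound 2 to compound 3 (within the scatter). Compound 3 is therefore estimated at 100 mg/kg, with a range from 50 mg/kg to 200 mg/kg.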

Compound 3, minimum effective dose: 30 mg/kg
Beside the measured number, compound 3's estimate is 3.3-fold (0.52 log units) above it; the measured number lies below the stated range.
By their numbers in this assay, from the lowest: compound 3; then compounds 1 and 2 (each within the scatter of the next).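

In this assay the choice of halogen does matter: where fluoro and chloro stood level, bromo brings a 3.3-fold lower number from compound 2 to compound 3 (0.52 log units; beyond the scatter) and a 3.3-fold lower number from compound 1 to compound 3 (0.52 log units; beyond the scatter) on this aromatic carbon. This position therefore responds to the halogen, with a smaller dose sufficing for the bromo compound, compound 3, than for the other two. No measurement shown here explains why bromo stands apart from fluoro and chloro. Going by these compounds, it remains open whether iodo would lower the dose further, and whether a group other than a halogen, such as methoxy or an amine, would match bromo here.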